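The source may report more compounds than this note shows. Statements on the series, on what has been measured and on what is new or still open speak of the compounds shown alone.

Compound 2 `CCCCCCCC/C=C\CCCCCCCCNC(=O)Nc1c(C)cccc1C` gives 160 nM in an assay on microsomes from intestinal mucosa for inhibition of acyl-CoA:cholesterol acyltransferase (Oryctolagus cuniculus) (on this read-out higher numbers stand for weaker inhibition and lower numbers for stronger inhibition), the lowest of the two single numbers recorded there. Its nearest neighbour on this read-out is compound 1 `CCCCCCCC/C=C\CCCCCCCCOC(=O)Nc1c(OC)cc(OC)cc1OC`, which gives 860 nM, a gap beyond the usual scatter. Compound 3 `CCCCCCCCCCCCCCCCCCNC(=O)Nc1c(C)cccc1C` gives 610 nM; 610 nM (2 entries) in two determinations, also above compound 2. Compound 4 `CCCCCCCC/C=C\CCCCCCCCNC(=O)Nc1c(Cl)cccc1Cl` has not yet been measured; it differs from compound 2 in one place: 2,6-dichlorophenyl in place of 2,6-dimethylphenyl on an amide-type nitrogen. For the measured compounds named here, no measured pair shows this exchange, so its effect is unknown. Compound 4 is expected to give roughly 200 nM, within a range of 80 nM to 500 nM, which corresponds to an expected step of a 1.3-fold higher number from compound 2 to compound 4 (0.10 log units; within the scatter), likely not beyond the scatter.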

Compound 4, half-maximal inhibitory concentration: 400 nM
Estimate against measurement, compound 4: 2.0-fold (0.30 log units) below; low and high end bracket the measured number.
By their numbers in this assay, from the lowest: compound 2; then compound 4; then compound 1.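

In this assay the change from 2,6-dimethylphenyl to 2,6-dichlorophenyl on the amide-type nitrogen gives a 2.5-fold higher number from compound 2 to compound 4 (0.40 log units; beyond the scatter) and so shows that this position responds to the exchange, although only modestly. The two groups match in heavy atoms and in hydrogen-bond donors and acceptors, so those counts do not account for the step. Nothing measured here gives a reason for it. On these data alone, whether plain phenyl or a phenyl ring carrying isopropyl groups would fare better remains open. So does whether the same exchange would give a similar step on the saturated chain of compound 3.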